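This account rests on a few compounds, and the source may have more. Where it says the series, first, only, none or still open, it means among the compounds named here.

Compound 2 `Cn1ncc2cc(-c3cnccc3/C=C/C(=O)N3CCOCC3)ccc21` stands at the high end of the three numbers measured in an assay on a protein complex for inhibition of CDK8/Cyclin C (Homo sapiens), with a stated time of 1 h (a higher number here means a weaker inhibitor, a lower number a stronger inhibitor), where compound 2 gives 356 nM. Its nearest neighbour is compound 3 `O=C(/C=C/c1ccncc1-c1ccc2cc[nH]c2c1)N1CCOCC1`, which in this assay gives 43.9 nM, and the furthest is compound 1 `NNC(=O)CCc1ccncc1-c1ccc2ccccc2c1`, which gives 7.7 nM. Compound 4 `CNC(=O)/C=C/c1ccncc1-c1ccc2c(cnn2C)c1` is not yet measured. It differs from compound 2 by a single change: methylamino in place of morpholin-4-yl on a carbonyl carbon. Within the data shown here, no measured pair shows this change, so the direction is open; a small step is expected, at most a modest move toward a lower number, with a 1.8-fold lower number from compound 2 to compound 4 (0.25 log units; within the scatter) as the expected shift. For compound 4 in this assay the estimate is 200 nM, within a range from 60 nM to 650 nM.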

Compound 4, half-maximal inhibitory concentration: 86.7 nM
Compound 4: middle estimate off by 2.3-fold (0.36 log units), on the high side, and the stated range covers the measured number.
By their numbers in this assay, from the lowest: compound 1; then compounds 3 and 4 (each within the scatter of the next); then compound 2.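

In this assay, among these compounds, methylamino in place of morpholin-4-yl on a carbonyl carbon gives a 4.1-fold lower number from compound 2 to compound 4 (0.61 log units; beyond the scatter) and so provides the first reading of a change at this position with the rest of the molecule held constant. At this position, the morpholine ring is not required for a number in this range. Nothing here explains the step.

A single pair cannot separate the loss of the ring from the gain of the amide hydrogen. Dimethylamino, which has no amide hydrogen, and an unsubstituted amino group on the same carbonyl carbon remain open.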